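This account rests on a few compounds, and the source may have more. Where it says the series, first, only, none or still open, it means among the compounds named here.

Compound 1 `Cn1ncnc1-c1ccccc1NCC1=NCCN1` — in an in vitro functional assay on cells (Fibroblast) for agonist activity at Alpha-1B adrenergic receptor (Homo sapiens) (on this read-out lower numbers stand for an effect already at smaller amounts and higher numbers for an effect only at larger amounts of compound), compound 1 gives 39.8 nM.
Compound 2 `CCCCn1ncnc1-c1ccccc1NCC1=NCCN1` — in this assay compound 2 gives 200 nM.
Compound 3 `CC(C)n1ncnc1-c1ccccc1NCC1=NCCN1` — in this assay compound 3 gives only a limit of the assay, < 100000 nM.

Among the two numbers available, compound 1 stands lowest; its nearest neighbour is compound 2, with a 5.0-fold higher number from compound 1 to compound 2 (0.70 log units; beyond the scatter). Compound 3 is not a number but a limit (the limit of < 100000 nM in this assay, at which 1 of the 3 values shown sits), so the step from compound 1 to compound 3 a step that the limit leaves unreadable from compound 1 to compound 3 and the step from compound 2 to compound 3 a step that the limit leaves unreadable from compound 2 to compound 3 cannot be read in size.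

Compound 4 `Cn1ccnc1-c1ccccc1NCC1=NCCN1` is the unmeasured compound. It differs from compound 1 by 1-methyl-1H-imidazol-2-yl in place of 1-methyl-1H-1,2,4-triazol-5-yl on an aromatic carbon. Both measured steps vary the chain on the aromatic nitrogen and leave the five-membered ring itself unchanged, so none of them speaks directly to an exchange of the ring. The data therefore give no direction for this change, and the expectation can only be that compound 4 stays close to compound 1, with a step of a 1.5-fold higher number from compound 1 to compound 4 (0.18 log units; within the scatter) expected, which is within the usual scatter. Compound 4 is thus estimated to give 60 nM in this assay, in a range from 15 nM to 300 nM.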

Compound 4, half-maximal effective concentration: 39.8 nM
For compound 4 the middle estimate is 1.5-fold (0.18 log units) above the measured one; the range from low to high includes it.
By their numbers in this assay, from the lowest: compounds 1 and 4 (each within the scatter of the next); then compound 2.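

Until now only the chain on the aromatic nitrogen had varied, while the five-membered ring stayed the same; compound 4 changes that ring itself, and in this assay 1-methyl-1H-imidazol-2-yl in place of 1-methyl-1H-1,2,4-triazol-5-yl gives no change at the digits printed from compound 1 to compound 4 (within the scatter). At this place on the aromatic carbon, then, a ring nitrogen can give way to carbon with no visible cost on this read-out, so the 1-methyl-1H-1,2,4-triazol-5-yl ring is not needed in exactly that form for the effect seen with compound 1. Nothing measured here offers a reason for this result.

Compound 3 gives only a limit, and the steps to it cannot be read in size: the limit of < 100000 nM in this assay, at which 1 of the 4 values shown sits.

From the compounds shown here alone, it also remains open whether the exchange holds with a butyl chain on the aromatic nitrogen, as in compound 2, and how a plain phenyl ring, an oxazole ring or a carboxylic acid would fare at this same place on the aromatic carbon.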